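Moving the hydroxyl around the ring: compound 3 to compound 4

The compounds below may be only part of what the source reports. "The series", "measured", "known", "first", "only" and "open" are said of these compounds alone.

Compound 1 `Oc1cccc(-c2cc(-c3ccccc3F)cc(-c3cccc(O)c3)n2)c1` and compound 2 `Oc1cccc(-c2cc(-c3ccccc3C(F)(F)F)cc(-c3cccc(O)c3)n2)c1` share a core that carries two 3-hydroxyphenyl groups on the ring with one nitrogen. In a functional assay on DU-145 cells (Homo sapiens) for inhibition (on this read-out higher numbers stand for weaker inhibition and lower numbers for stronger inhibition), compound 1 gives 11200 nM and compound 2 gives 2870 nM, so that the exchange of fluoro for trifluoromethyl brought a 3.9-fold lower number from compound 1 to compound 2 (0.59 log units; beyond the scatter). Compound 3 `Oc1cccc(-c2cc(-c3ccccc3OC(F)(F)F)cc(-c3ccccc3O)n2)c1` differs from both in having one 2-hydroxyphenyl group instead of a 3-hydroxyphenyl group and a trifluoromethoxy group on the third ring. For compound 3 this assay reports only a limit, > 50000 nM, the upper limit at which one of the three values shown sits (the limit of > 50000 nM in this assay, at which 1 of the 3 values shown sits).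

Compound 4 `Oc1cccc(-c2cc(-c3ccccc3OC(F)(F)F)cc(-c3cccc(O)c3)n2)c1` is built from the same atoms as compound 3, joined differently: 3-hydroxyphenyl in place of 2-hydroxyphenyl on an aromatic carbon. With this change compound 4 carries the same pair of 3-hydroxyphenyl groups as compound 1 and compound 2, both of which gave a measurable number in this assay. Within the data shown here, the one measured step concerns a different position and does not bear directly on this change. Compound 4 is therefore expected to move from the limit to a measurable value, an estimated step of an at least 5.0-fold lower number from compound 3 to compound 4 (0.69 log units; beyond the scatter), giving an estimate of 10000 nM with a range from 2500 nM to 40000 nM.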

Compound 4, half-maximal inhibitory concentration: 5420 nM
Compound 4: middle estimate off by 1.8-fold (0.27 log units), on the high side, and the stated range covers the measured number.
By their numbers in this assay, from the lowest: compounds 2 and 4 (each within the scatter of the next); then compound 1. At a limit, above all of these: compound 3.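

In this assay the swap at this position counts for a great deal: 3-hydroxyphenyl in place of 2-hydroxyphenyl gives an at least 9.2-fold lower number from compound 3 to compound 4 (0.96 log units; beyond the scatter) in the first step shown at this position. That size is only a floor, because compound 3 stands at a limit of the assay: the limit of > 50000 nM in this assay, at which 1 of the 4 values shown sits. With both 3-hydroxyphenyl groups present, trifluoromethoxy can also be set against the other two groups on the third ring, where a 1.9-fold higher number from compound 2 to compound 4 (0.28 log units; within the scatter) leaves it level with trifluoromethyl and a 2.1-fold lower number from compound 1 to compound 4 (0.32 log units; beyond the scatter) puts it ahead of fluoro.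

Going by these compounds, only compound 3 carries a 2-hydroxyphenyl group, so it stays open whether the same swap would count as much with fluoro or trifluoromethyl on the third ring. Also open, on these data alone, is how a 4-hydroxyphenyl group, or an amine or methoxy in place of the hydroxyl, would read here.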